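Shortening benzyloxycarbonyl to methoxycarbonyl

A few compounds are considered here, and "the series" means these few. Any claim that something is new, unique, unknown or untested is made for them only; others in the source may bear on it.

Going by the values given here, in an ADME assay on a cell-free system (plasma, Homo sapiens) for metabolic stability, read by LC-MS (a lower number here means that the compound disappears faster, a higher number that the compound lasts longer), compound 2 (`NCc1ccc(C(=O)Nc2ccncc2)cc1-c1cccc(C(=O)OCc2ccccc2)c1`) gives 1.07 h as the higher of the two numbers so far. Compound 1 (`NCc1ccc(C(=O)Nc2ccncc2F)cc1-c1cccc(C(=O)OCC2CC2)c1`) gives 0.3 h and lies beyond the scatter from it.

Compound 3 (`COC(=O)c1cccc(-c2cc(C(=O)Nc3ccncc3)ccc2CN)c1`) comes from compound 2 by a single change, benzyloxycarbonyl to methoxycarbonyl, with hydrogen in place of phenyl on a saturated chain carbon bound to an oxygen next to a carbonyl group. Among the compounds with values here, no measured pair isolates this change: compound 1 and compound 2 differ in more than one place, so the size of the step rests on judgement and the range stays wide.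

In this assay a small upward step is expected, a 1.4-fold higher number from compound 2 to compound 3 (0.15 log units; within the scatter) and within the scatter. Compound 3 is estimated at 1.5 h with an expected range of 0.4 h to 5 h in repeat measurements.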

Compound 3, half-life: 1.52 h
For compound 3 the middle estimate is 1.0-fold (0.01 log units) below the measured one, within the range that was stated.
By their numbers in this assay, from the lowest: compound 1; then compounds 2 and 3 (each within the scatter of the next).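

With a 1.4-fold higher number from compound 2 to compound 3 (0.15 log units; within the scatter) as the step, this assay gains its first comparison of compounds that differ in one place. At this position, benzyloxycarbonyl and methoxycarbonyl cannot be told apart in this read-out, even though phenyl, with its 6 heavy atoms, is replaced by hydrogen on the saturated chain carbon. Nothing on hand explains this result.

Compound 1 differs from compound 2 and from compound 3 in more than one place, so its steps cannot be read. As far as these compounds go, it remains open how an amine, a carboxylic acid or a longer chain in place of the methyl of methoxycarbonyl would stand in this assay against compound 2 and compound 3.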